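A few compounds are considered here, and "the series" means these few. Any claim that something is new, unique, unknown or untested is made for them only; others in the source may bear on it.

Working notes on the series, read in a functional assay on A549 cells (Homo sapiens) for inhibition, read by sulforhodamine B assay; on this read-out higher numbers stand for weaker inhibition of growth and lower numbers for stronger inhibition of growth. Compound 1 `c1ccc(-c2ccc(-c3ccc(-c4nc5ccccc5[nH]4)cc3)cc2)cc1` gives 41200 nM, and compound 3 `Fc1ccc(-c2ccc(-c3ccc(-c4nc5ccccc5[nH]4)cc3)cc2)cc1` gives 33200 nM. These two values lie within the scatter of each other. Compound 2 `Cc1ccc2[nH]c(-c3ccc(-c4ccc(-c5cccc(Cl)c5)cc4)cc3)nc2c1` gives 2800 nM, and the other two numbers are both much higher. Compound 3 therefore belongs with compound 1 at the weak end of this small set.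

The next compound is compound 4 `COc1ccc(-c2ccc(-c3ccc(-c4nc5ccccc5[nH]4)cc3)cc2)cc1`, with methoxy in place of fluoro on an aromatic carbon, para to a large group (methoxy in place of fluoro on an aromatic carbon). Within the data shown here, one measured step bears on this place: a 1.2-fold lower number from compound 1 to compound 3 (0.09 log units; within the scatter), where fluoro replaced hydrogen, and it stayed within the scatter. Compound 2 differs from compound 3 in more than one place, so it gives no clean guide here. Among the measured compounds shown here, no methoxy compound has been measured yet, so the evidence is thin. No step beyond the scatter is expected in this assay. The expected step is a 1.1-fold lower number from compound 3 to compound 4 (0.04 log units; within the scatter). For compound 4 the estimated value is 30000 nM, with an expected range of 12000 nM to 65000 nM.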

Compound 4, concentration for 50% growth inhibition: 38100 nM
Beside the measured number, compound 4's estimate is 1.3-fold (0.10 log units) below it; the range from low to high includes it.
By their numbers in this assay, from the lowest: compound 2; then compounds 3, 4 and 1 (each within the scatter of the next).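

In this assay the change from 4-fluorophenyl to 4-methoxyphenyl gives a 1.1-fold higher number from compound 3 to compound 4 (0.06 log units; within the scatter), and methoxy in place of hydrogen gives a 1.1-fold lower number from compound 1 to compound 4 (0.03 log units; within the scatter). This aromatic carbon, para to a large group, has now carried hydrogen, fluoro and methoxy with all three compounds within the scatter of one another, so the tolerance seen with fluoro also holds for a group of two heavy atoms with one hydrogen-bond acceptor. No measurement available here accounts for this result.

On these data alone, whether an amine, a carboxylic acid or a longer chain at this place would give a step beyond the scatter remains open. As far as these compounds go, compound 2 differs from these compounds in more than one place, so the separate contributions of its chloro and methyl groups also remain open.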